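A few compounds are considered here, and "the series" means these few. Any claim that something is new, unique, unknown or untested is made for them only; others in the source may bear on it.

Of the compounds shown here, two have so far been measured in a functional assay on SK-MEL-28 cells (Homo sapiens) for inhibition, read by sulforhodamine B assay, with a stated time of 48 h, tested at 1 uM; on this read-out lower numbers stand for a stronger effect and higher numbers for a weaker effect at the one concentration tested. Compound 1 `COc1cc(Cl)cc(-c2nn(-c3cccc(NC(=O)Nc4ccc(Cl)c(C(F)(F)F)c4)c3)cc2-c2ccncc2)c1` gives 85% in this assay, the lowest of the two numbers. Compound 2 `COc1cc(Cl)cc(-c2nn(-c3cccc(NC(=O)c4cccc(C(F)(F)F)c4)c3)cc2-c2ccncc2)c1`, which carries a 3-(trifluoromethyl)phenyl in place of a (4-chloro-3-(trifluoromethyl)phenyl)amino on the carbonyl carbon, gives 92% in this assay; the step of a number 7 percentage points higher from compound 1 to compound 2 (within the scatter) lies within the scatter. The compound now in question, compound 3 `O=C(Nc1cccc(-n2cc(-c3ccncc3)c(-c3cc(O)cc(Cl)c3)n2)c1)Nc1ccc(Cl)c(C(F)(F)F)c1`, differs from compound 1 at another place: hydrogen in place of methyl on an oxygen on an aromatic ring. No measured step touches this oxygen, so nothing shown points in either direction; the only measured step, at the carbonyl carbon, was small. Because compound 1 gives 85% in this assay, compound 3 is expected to give an estimated 85% in this assay, with a range from 70% to 98%. The expected step of no change at the digits printed from compound 1 to compound 3 (within the scatter) is thus estimated to stay within the scatter.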

Compound 3, a percentage reported as activity, at one concentration (the size of the read-out at that concentration, not a potency): 81%
Estimate against measurement, compound 3: 4 percentage points above, within the range that was stated.
By their numbers in this assay, from the lowest: compounds 3, 1 and 2 (each within the scatter of the next, the first and the last beyond it).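

In this assay, within the data shown here, the first measured change at this oxygen, from methoxy to hydroxy, gives a number 4 percentage points lower from compound 1 to compound 3 (within the scatter). Removing the methyl therefore leaves compound 3 indistinguishable from compound 1 at the one concentration tested, so on this shared core, this read-out does not separate a 3-chloro-5-methoxyphenyl from a 3-chloro-5-hydroxyphenyl. No supporting measurement bears on why the two compounds read alike.

From the compounds shown here alone, it remains open whether a different group at this place, such as an ethoxy, a longer chain on the oxygen or an amine in place of the oxygen, would move the number beyond the scatter. Going by these compounds, it is also open whether the same change from methoxy to hydroxy would read alike on compound 2, which has a different group on the carbonyl carbon.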